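A plain phenyl replaces a substituted ring in compound 2

A few compounds are considered here, and "the series" means these few. Any claim that something is new, unique, unknown or untested is made for them only; others in the source may bear on it.

Compound 1 `CCOc1cc(C=C(C(=O)/C=C/c2ccc(O)c(OC)c2)C(=O)/C=C/c2ccc(O)c(OC)c2)ccc1O`: 3980 nM
Compound 2 `CCOc1cc(/C=C/C(=O)C(=Cc2ccc(O)c(OC)c2)C(=O)/C=C/c2ccc(O)c(OCC)c2)ccc1O`: 5360 nM

In a functional assay, read by spectrophotometry, with a stated time of 5 min (a higher number here means a weaker inhibitor, a lower number a stronger inhibitor), compound 2 gives 5360 nM, which stands level with compound 1, the two values lying within the scatter of each other. Compound 3 `CCOc1cc(/C=C/C(=O)C(=Cc2ccccc2)C(=O)/C=C/c2ccc(O)c(OCC)c2)ccc1O` has not yet been measured. It differs from compound 2 by phenyl in place of 4-hydroxy-3-methoxyphenyl on a double-bonded chain carbon bound to a double-bonded chain carbon, with phenyl in place of 4-hydroxy-3-methoxyphenyl on a double-bonded chain carbon bound to a double-bonded chain carbon. Going by the values given here, no measured pair isolates this change, so no step beyond the scatter is expected in this assay. The expected change is a 1.1-fold higher number from compound 2 to compound 3 (0.05 log units; within the scatter). For compound 3 the estimated value is 6000 nM, with an expected range of 2500 nM to 15000 nM.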

Compound 3, half-maximal inhibitory concentration: 20400 nM
Estimate against measurement, compound 3: 3.4-fold (0.53 log units) below; the measured number lies above the stated range.
By their numbers in this assay, from the lowest: compounds 1 and 2 (each within the scatter of the next); then compound 3.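

In this assay, phenyl in place of 4-hydroxy-3-methoxyphenyl on a double-bonded chain carbon bound to a double-bonded chain carbon weakens inhibition (a 3.8-fold higher number from compound 2 to compound 3 (0.58 log units; beyond the scatter)). This is the first step shown that lies beyond the scatter, so this position does respond to a change of its ring substituents. Nothing measured here accounts for the step. The compounds shown leave open whether the hydroxy group, the methoxy group or both matter. They also leave open whether an amine or a carboxylic acid on this ring would restore inhibition.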